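The compounds below may be only part of what the source reports. "The series", "measured", "known", "first", "only" and "open" are said of these compounds alone.

Measured compounds in an assay on isolated protein for inhibition of Rho-associated protein kinase 2 (Homo sapiens), read by radiometric assay; a higher number here means a weaker inhibitor, a lower number a stronger inhibitor:
- compound 1, `CCCCOC(=O)c1cccc(-c2cc(C(=O)Nc3ccncc3)ccc2CN)c1`: 5.5 nM
- compound 2, `NCc1ccc(C(=O)Nc2ccncc2)cc1-c1cccc(C(=O)OCc2ccccc2)c1`: 45 nM
- compound 3, `CC(C)OCCOC(=O)c1cccc(-c2cc(C(=O)Nc3ccncc3F)ccc2CN)c1`: 37 nM

Compound 3 stands second highest of the three numbers in this assay. Its nearest neighbour is compound 2, whose number lies within the scatter of it, so no order between the two can be read; compound 1 sits clearly lower, beyond the scatter.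

Compound 4, `COC(=O)c1cccc(-c2cc(C(=O)Nc3ccncc3F)ccc2CN)c1`, is not yet measured. It differs from compound 3 by hydrogen in place of isopropoxymethyl on a saturated chain carbon bound to an oxygen next to a carbonyl group, so the ester is cut back to a methoxycarbonyl. Among the compounds with values here, the only measured step that touches the same place is an 8.2-fold higher number from compound 1 to compound 2 (0.91 log units; beyond the scatter), where a larger group on that saturated chain carbon went with a higher number. Whether shrinking the group instead moves the number down, or leaves it inside the scatter, cannot be settled from one step; a small drop is the more plausible reading, though the pair compound 1 and compound 3 also differ at the pyridine ring and so does not isolate the ester.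

For compound 4 the expected step is a 1.5-fold lower number from compound 3 to compound 4 (0.17 log units; within the scatter), and the estimated value in this assay is 25 nM with a range of 8 nM to 80 nM.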

Compound 4, half-maximal inhibitory concentration: 7.8 nM
Compound 4: middle estimate off by 3.2-fold (0.51 log units), on the high side, and the stated range ends above it.
By their numbers in this assay, from the lowest: compounds 1 and 4 (each within the scatter of the next); then compounds 3 and 2 (each within the scatter of the next).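

In this assay, cutting (2-isopropoxyethoxy)carbonyl back to methoxycarbonyl gives a 4.7-fold lower number from compound 3 to compound 4 (0.68 log units; beyond the scatter) and so shows that this place on the ester responds to removing a group, not only to changing one. Read with an 8.2-fold higher number from compound 1 to compound 2 (0.91 log units; beyond the scatter) on the non-fluorinated compounds, both single-place steps put the larger group with the higher number, and neither pair goes against this, though two pairs are a thin basis for a trend.

Open, from the compounds shown here alone, is whether chain length or the ether oxygen of the 2-isopropoxyethyl group carries the step, which an ethyl ester or a plain hexyl ester would help separate. Also open, going by these compounds, is whether the ester itself matters at this place, as a carboxylic acid or a primary amide there would test. No measurement offered here gives a cause for the step.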